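Branching the Nitrogen Substituent: From Propyl to Isopropyl

The source may report more compounds than this note shows. Statements on the series, on what has been measured and on what is new or still open speak of the compounds shown alone.

For the measured compounds named here, compound 2 `CCCC(C(C)C)n1ccc2cc(/C(C)=C/C(=O)Nc3ccccc3OCCCC(=O)O)ccc21` gives 7.2 nM in an assay on Prostate gland for inhibition of steroid 5-alpha-reductase (Rattus norvegicus) (a lower number here means a stronger inhibitor, a higher number a weaker inhibitor), the lowest of the two numbers known so far; compound 1 `C/C(=C\C(=O)Nc1ccccc1OCCCC(=O)O)c1ccc2c(ccn2C)c1` gives 780 nM. Going by the values given here, the only measured step, a 110-fold lower number from compound 1 to compound 2 (2.03 log units; beyond the scatter), changes a methyl on an aromatic nitrogen into a large branched group. Compound 3 `C/C(=C\C(=O)Nc1ccccc1OCCCC(=O)O)c1ccc2c(ccn2C(C(C)C)C(C)C)c1` differs from compound 2 by isopropyl in place of propyl on a saturated chain carbon bound to an aromatic nitrogen and a saturated chain carbon. Among the compounds with values here, no measured step tests a rearrangement inside an already large group, so nothing beyond the scatter is expected. Compound 3 is estimated at 8 nM, between 3 nM and 25 nM. The estimated step is a 1.1-fold higher number from compound 2 to compound 3 (0.05 log units; within the scatter).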

Compound 3, half-maximal inhibitory concentration: 14 nM
For compound 3 the middle estimate is 1.8-fold (0.24 log units) below the measured one; the measured number falls inside the stated range.
By their numbers in this assay, from the lowest: compounds 2 and 3 (each within the scatter of the next); then compound 1.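

Swapping propyl for isopropyl on the saturated chain carbon gives a 1.9-fold higher number from compound 2 to compound 3 (0.29 log units; within the scatter) in this assay and so does not separate the two, even though the same carbon atoms are joined differently. The large difference from the small methyl group remains after this rearrangement, with a 56-fold lower number from compound 1 to compound 3 (1.75 log units; beyond the scatter) on the aromatic nitrogen. No measurement at hand gives a reason for either step. Still open, on these data alone, is how an ethyl or a cyclohexyl group on that nitrogen would compare, and whether an amine on the branched group would keep the number low.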